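Changing the Aryl Ketone Group in a Furyl-Bearing Series

This account rests on a few compounds, and the source may have more. Where it says the series, first, only, none or still open, it means among the compounds named here.

Measured compounds:
compound 1 `COc1cc(C(=O)C2Sc3nnc(-c4cc(OC)c(OC)c(OC)c4)n3NC2c2ccco2)cc(OC)c1OC` — 48300 nM
compound 2 `COc1cc(-c2nnc3n2NC(c2ccco2)C(C(=O)c2ccccc2F)S3)cc(OC)c1OC` — 78700 nM
compound 3 `COc1cc(-c2nnc3n2NC(c2ccco2)C(C(=O)c2ccc(Cl)cc2)S3)cc(OC)c1OC` — 51400 nM

In a functional assay on A549 cells (Homo sapiens) for cytotoxicity, read by MTT assay, with a stated time of 48 h (on this read-out lower numbers stand for stronger inhibition and higher numbers for weaker inhibition), compound 1 gives the lowest of the three numbers, yet the other two sit close to it: a 1.1-fold higher number from compound 1 to compound 3 (0.03 log units; within the scatter) and a 1.6-fold higher number from compound 1 to compound 2 (0.21 log units; within the scatter). Between the two variants there is likewise little to separate them, since a 1.5-fold lower number from compound 2 to compound 3 (0.19 log units; within the scatter). All three numbers therefore describe weak inhibition of roughly the same size, and none of the compounds can be called more or less active than another.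

Compound 4 `COc1cc(-c2nnc3n2NC(c2ccco2)C(C(=O)c2ccccc2)S3)cc(OC)c1OC` is the next variant of the shared core. Compared with compound 1 it carries phenyl in place of 3,4,5-trimethoxyphenyl on a carbonyl carbon. Going by the values given here, the steps that bear on this change are the two in which other aromatic rings replaced the 3,4,5-trimethoxyphenyl on the carbonyl carbon, namely the steps from compound 1 to compound 2 and from compound 1 to compound 3, both of which stayed within the scatter. Exchanging this ring for a phenyl is therefore expected to give, in this assay, a number for compound 4 that again does not move beyond the scatter, a 1.2-fold higher number from compound 1 to compound 4 (0.09 log units; within the scatter). The estimate for compound 4 is 60000 nM, with a range from 30000 nM to 120000 nM.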

Compound 4, half-maximal inhibitory concentration: 33400 nM
For compound 4 the middle estimate is 1.8-fold (0.25 log units) above the measured one, within the range that was stated.
By their numbers in this assay, from the lowest: compounds 4, 1, 3 and 2 (each within the scatter of the next, the first and the last beyond it).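

Going from the 3,4,5-trimethoxyphenyl to a bare phenyl on the carbonyl carbon leaves this group with fewer heavy atoms and removes its 3 hydrogen-bond acceptors, yet this assay gives a 1.4-fold lower number from compound 1 to compound 4 (0.16 log units; within the scatter), so this position accepts the unsubstituted ring as well as the larger one. Going by these compounds alone, replacing chloro with hydrogen on an aromatic carbon gives a 1.5-fold lower number from compound 3 to compound 4 (0.19 log units; within the scatter), whereas replacing fluoro with hydrogen gives a 2.4-fold lower number from compound 2 to compound 4 (0.37 log units; beyond the scatter), the first step in this set to pass the scatter, although only modestly. Nothing available here accounts for that single larger step.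

On these data alone, all four compounds still keep an aromatic carbon ring on the carbonyl carbon, so it remains open whether a saturated cyclohexyl group or a short chain such as ethyl would serve there. As far as these compounds go, it is also open whether a phenyl ring bearing an amine or a carboxylic acid would move the number further than the halogens and methoxy groups do.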